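Guanidine series: cyclohexyl on the amine nitrogen of compound 3

This account rests on a few compounds, and the source may have more. Where it says the series, first, only, none or still open, it means among the compounds named here.

compound 1 `CCOC(=O)N/C(=N\CCC(c1ccc(F)cc1)c1ccccn1)NCCCc1c[nH]cn1` — 5.3
compound 2 `c1ccc(C(CCC/N=C(/NCCCc2c[nH]cn2)NC2CCCCC2)c2ccccn2)cc1` — 5.56
compound 3 `Cc1ccc(CC(CC/N=C(\N)NCCCc2c[nH]cn2)c2ccccn2)cc1` — 6.4

In a functional assay on ileum for antagonist activity at histamine H1 receptor (Cavia porcellus) (a higher number here means a more potent compound, by a factor of ten per unit of this negative logarithm, a lower number a less potent compound), compound 3 gives 6.4, the highest of the three numbers; compound 2 sits lower and compound 1 lower still, both gaps beyond the scatter. Compound 4 `Cc1ccc(CC(CC/N=C(/NCCCc2c[nH]cn2)NC2CCCCC2)c2ccccn2)cc1` differs from compound 3 in one place: cyclohexyl in place of hydrogen on an amine nitrogen. For the measured compounds named here, no measured pair shows this same change on a shared frame, so its size is not known directly. Compound 2, which also carries a cyclohexyl on an amine nitrogen but in a different frame, gives 5.56, a number that points downward rather than upward. A modest decrease is therefore expected, as the step of a number 0.50 log units lower from compound 3 to compound 4 (beyond the scatter). Compound 4 is estimated at 5.9, within 5.3 to 6.5.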

Compound 4, negative logarithm of the antagonist equilibrium constant: 5.4
The estimate for compound 4 lay 0.50 log units above the measured number; the measured number falls inside the stated range.
By their numbers in this assay, from the lowest: compounds 1, 4 and 2 (each within the scatter of the next); then compound 3.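

Cyclohexyl in place of hydrogen on an amine nitrogen now has a direct reading in this assay, with a number 1.00 log units lower from compound 3 to compound 4 (beyond the scatter) on a shared frame. At this position, the free amino form of compound 3 holds the higher number, and the cyclohexylamino form of compound 4 does not keep it. Nothing at hand explains the drop.

As far as these compounds go, whether methyl, ethyl or benzyl on that nitrogen would keep the number of compound 3 remains open. Also open, from the compounds shown here alone, is whether the same change gives a similar step on the frame of compound 2.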